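The source may report more compounds than this note shows. Statements on the series, on what has been measured and on what is new or still open speak of the compounds shown alone.

Within the data shown here, in a functional assay on ileum (strain Hartley) for agonist activity at 5-hydroxytryptamine receptor 3A (Cavia porcellus) (a higher number here means a more potent compound, by a factor of ten per unit of this negative logarithm, a lower number a less potent compound), compound 2 `CN1CCN(c2nc3cc(F)ccc3o2)CC1` gives 5.57, the only plain number found so far. Compound 1 `CN1CCN(c2nc3cc(C(F)(F)F)ccc3o2)CC1` gives only a limit of this assay, < 4. Among the measured compounds shown here, the single measured step, a number at least 1.57 log units higher from compound 1 to compound 2 (beyond the scatter), is the only guide, and it leaves compound 1 at the limit (the limit of < 4 in this assay, at which 1 of the 2 values shown sits). Compound 3 `CN1CCN(c2nc3cc(N)ccc3o2)CC1` differs from compound 2 by amino in place of fluoro on an aromatic carbon. For the measured compounds named here, no measured step exchanges fluoro for amino, so the expected step of a number 0.17 log units lower from compound 2 to compound 3 (within the scatter) is none beyond the scatter, with wide uncertainty. Compound 3 is therefore estimated at 5.4, between 4.5 and 6.3.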

Compound 3, negative logarithm of the half-maximal effective concentration: 4.97
Compound 3: middle estimate off by 0.43 log units, on the high side; the measured number falls inside the stated range.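

In this assay, amino in place of fluoro on an aromatic carbon gives a number 0.60 log units lower from compound 2 to compound 3 (beyond the scatter), so this position distinguishes even between two single-atom groups. Amino in place of trifluoromethyl gives a number at least 0.97 log units higher from compound 1 to compound 3 (beyond the scatter), which places compound 3 between the other two compounds and shows that activity at this position is graded. The value for compound 1 is still a limit and not a number: the limit of < 4 in this assay, at which 1 of the 3 values shown sits.

As far as these compounds go, how a hydroxyl, a methoxy or a methyl group at this position would compare with fluoro and amino remains open. So does the effect of plain hydrogen there.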